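This account rests on a few compounds, and the source may have more. Where it says the series, first, only, none or still open, it means among the compounds named here.

In an ADME assay on Raji cells (Homo sapiens) for cytotoxicity, read by CellTiter-Glo, with a stated time of 72 h (on this read-out lower numbers stand for an effect already at smaller amounts and higher numbers for an effect only at larger amounts of compound), compound 1 `CC1=C2CC(C)(C)/C=C/[C@H](O)/C(C)=C\C3=C[C@H](C)C[C@]3(O2)C1=O` gives 26000 nM, and compound 2 `CC(=O)O[C@H]1/C=C/C(C)(C)CC2=C(C)C(=O)[C@]3(C[C@@H](C)C=C3/C=C\1C)O2` stands level with it at 26000 nM. Compound 3 `CC1=C2CC(C)(C)/C=C/[C@H](OC(=S)n3ccnc3)/C(C)=C\C3=C[C@H](C)C[C@]3(O2)C1=O` changes the same oxygen on a saturated carbon: a group of 7 heavy atoms (4 carbon, 2 nitrogen, 1 sulfur; one five-membered aromatic ring with 2 hetero atoms) in place of a group of 3 heavy atoms (2 carbon, 1 oxygen; no ring), on an oxygen on a saturated carbon. For the measured compounds named here, the only measured step bearing on this is no change at the digits printed from compound 1 to compound 2 (within the scatter), also made on that oxygen. Going by the values given here, no measured step places a ring there, so this evidence is thin and the range stays wide. The expected step is a 1.3-fold lower number from compound 2 to compound 3 (0.11 log units; within the scatter), with nothing beyond the scatter anticipated. Compound 3 is estimated at 20000 nM, with an expected range of 6000 nM to 45000 nM.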

Compound 3, half-maximal effective concentration: 26000 nM
Compound 3: the middle estimate sits 1.3-fold (0.11 log units) below what was measured; low and high end bracket the measured number.
By their numbers in this assay, from the lowest: compounds 1, 2 and 3 (each within the scatter of the next).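

In this assay the oxygen on a saturated carbon now carries a group with one five-membered aromatic ring with 2 hetero atoms, and the reading gives no change at the digits printed from compound 2 to compound 3 (within the scatter) and no change at the digits printed from compound 1 to compound 3 (within the scatter). Where the earlier pair set only acetyl against hydrogen, a ring-bearing group now joins them without a step beyond the scatter. No supporting data explain this flat reading. From the compounds shown here alone, whether a carboxylic acid or an amine on a longer chain at this oxygen would move the number stays open, as does any change elsewhere on the shared core.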